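This account rests on a few compounds, and the source may have more. Where it says the series, first, only, none or still open, it means among the compounds named here.

Series notes. Compound 1 `CC(CCCCCCc1ccccc1)CC(C)C[C@]1(C)C[C@]2(C)OC(=O)C[C@@H]2OO1` is the weaker of the two measured compounds: in a functional assay on cells (Homo sapiens) for cytotoxicity against EL4 (Mus musculus) (a lower number here means a stronger inhibitor, a higher number a weaker inhibitor), compound 1 gives 15.8 ug/mL, the higher of the two numbers. Compound 2 `CCCCCCCCCCCCCCCC[C@@]1(OC)C=C[C@@H](CC(=O)OC)OO1` gives 0.4 ug/mL in this assay, a gap beyond the scatter. Compound 3 `CC(CCCCCCCCc1ccccc1)C[C@]1(C)C[C@]2(C)OC(=O)C[C@@H]2OO1` differs from compound 1 by hydrogen in place of methyl on a saturated chain carbon bound to two saturated chain carbons. Within the data shown here, no measured pair shows this kind of change, so the expected step of a 1.1-fold lower number from compound 1 to compound 3 (0.02 log units; within the scatter) is small and within the scatter, with no direction favoured. For compound 3 the estimated value in this assay is 15 ug/mL, within 6 ug/mL to 40 ug/mL.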

Compound 3, half-maximal inhibitory concentration: 4.4 ug/mL
Beside the measured number, compound 3's estimate is 3.4-fold (0.53 log units) above it; the whole stated range lies above it.
By their numbers in this assay, from the lowest: compound 2; then compound 3; then compound 1.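

In this assay, among these compounds, hydrogen in place of methyl on a saturated chain carbon bound to two saturated chain carbons gives a 3.6-fold lower number from compound 1 to compound 3 (0.56 log units; beyond the scatter), the first single-place step. This chain position therefore responds to the loss of one methyl, so the methyl on this carbon is not neutral here. Nothing on hand accounts for the step.

Open, from the compounds shown here alone, is whether an ethyl or a hydroxyl group on this carbon would move the number further or reverse it. Going by these compounds, whether the same change gives a similar step on the core of compound 2 also remains open.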